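The compounds below may be only part of what the source reports. "The series", "measured", "known", "first", "only" and "open" are said of these compounds alone.

Measured so far:
- Compound 1, `Cc1ccccc1C#Cc1ccc2c(n1)CCN(C(C)C)C2=O`: > 32000 nM in an assay on HEK293 cells for displacement of a labelled ligand from metabotropic glutamate receptor 5 (Homo sapiens), with a stated time of 2 h; on this read-out lower numbers stand for stronger inhibition and higher numbers for weaker inhibition
- Compound 2, `CC(C)N1CCc2nc(C#Cc3ccccn3)ccc2C1=O`: 2740 nM in this assay

The value of compound 1 is a limit of the assay rather than a number, namely (the limit of > 32000 nM in this assay, at which 1 of the 2 values shown sits). Compound 2 therefore holds the only number shown, and it cannot be ranked against another number. Among the compounds with values here, the one measured step, an at least 11-fold lower number from compound 1 to compound 2 (1.06 log units; beyond the scatter), exchanged the ring on the triple-bonded carbon and produced a large gain.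

Compound 3, `CC(C)N1CCc2nc(C#Cc3cccs3)ccc2C1=O`, differs from compound 2 in one place: thiophen-2-yl in place of pyridin-2-yl on a triple-bonded carbon. Within the data shown here, the measured step is the only guide, and it concerned the same position; it was large, but it swapped a ring without a hetero atom for one with a hetero atom, whereas here one ring with a single hetero atom gives way to another. A step of smaller size is expected, leaning toward a weaker result. For compound 3 the expected step is a 2.2-fold higher number from compound 2 to compound 3 (0.34 log units; beyond the scatter). Compound 3 is therefore estimated at 6000 nM, within a range from 1500 nM to 25000 nM.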

Compound 3, inhibition constant: 1930 nM
For compound 3 the middle estimate is 3.1-fold (0.49 log units) above the measured one; the range from low to high includes it.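

Exchanging pyridin-2-yl for thiophen-2-yl on the triple-bonded carbon gives a 1.4-fold lower number from compound 2 to compound 3 (0.15 log units; within the scatter) in this assay, so a six-membered ring containing nitrogen and a five-membered ring containing sulfur cannot be told apart on this read-out. The large step seen earlier also appears with this second ring, as replacing 2-methylphenyl with thiophen-2-yl gives an at least 16-fold lower number from compound 1 to compound 3 (1.21 log units; beyond the scatter), which means that this step does not require the nitrogen of pyridin-2-yl. Compound 1 holds a limit of the assay rather than a number, so both large steps give only the least possible size of the change: the limit of > 32000 nM in this assay, at which 1 of the 3 values shown sits.

The compounds shown leave open whether the poor result of compound 1 comes from its methyl group or from its ring having no hetero atom, a question that plain phenyl at this position could help to separate. From the compounds shown here alone, it also remains open how this position would respond to a pyridine or thiophene ring carrying an amine or a carboxylic acid, or to a simple alkyl chain in place of the ring.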